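Hydroxy removal on the aryl ring of compound 1

The compounds below may be only part of what the source reports. "The series", "measured", "known", "first", "only" and "open" are said of these compounds alone.

Compound 1 `COc1ccc(C(=O)C2=CCCc3c2cc(OC)c(OC)c3OC)c(O)c1O` in a functional assay on NCI-H460 cells (Homo sapiens) for inhibition, read by sulforhodamine B assay, with a stated time of 48 h (on this read-out lower numbers stand for stronger inhibition of growth and higher numbers for weaker inhibition of growth), gives 2800 nM. Compound 2 `COc1ccc2c(c1)CCCC(c1cc(OC)c(OC)c(OC)c1)=C2` in this assay gives 470 nM, and compound 3 `COc1ccc2c(c1O)CCCC(c1cc(OC)c(OC)c(OC)c1)=C2` gives 1200 nM. The step of a 2.6-fold lower number from compound 3 to compound 2 (0.41 log units; beyond the scatter) comes from the change (hydrogen in place of hydroxy on an aromatic carbon). How the core of compound 1 differs from that of compound 3 is not broken down here. Compound 4 `COc1ccc(C(=O)C2=CCCc3c2cc(OC)c(OC)c3OC)cc1O` arises from compound 1 by hydrogen in place of hydroxy on an aromatic carbon. The surroundings differ: in compound 3 the carbon is part of a fused or bridged system of two rings, ortho to a fused ring, ortho to a methoxy group and meta to a fused ring; in compound 1 it is ortho to a hydroxy group, ortho to a large group and meta to a methoxy group. It is the same kind of change, not the same. A step of a 2.0-fold lower number from compound 1 to compound 4 (0.30 log units; within the scatter) is expected, resting on a 2.6-fold lower number from compound 3 to compound 2 (0.41 log units; beyond the scatter) and tempered by the different place. Compound 4 is estimated at 1400 nM, between 500 nM and 4000 nM.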

Compound 4, concentration for 50% growth inhibition: 6000 nM
Beside the measured number, compound 4's estimate is 4.3-fold (0.63 log units) below it, outside the stated range (above it).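

Hydrogen in place of hydroxy, on the aromatic carbon ortho to a hydroxy group and ortho to a large group, gives a 2.1-fold higher number from compound 1 to compound 4 (0.33 log units; beyond the scatter) in this assay. The change therefore does not carry over from one core to the other in this assay, and its direction reverses: the same change on two cores in this assay, a 2.6-fold lower number (0.41 log units; beyond the scatter) from compound 3 to compound 2 and a 2.1-fold higher number (0.33 log units; beyond the scatter) from compound 1 to compound 4, 5.5-fold (0.74 log units) apart, beyond the scatter of two such steps. With one pair on each core, and the surroundings of the carbon differing as well as the core, these compounds do not separate the effect of the core from that of the place, and they give no cause for the reversal.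

Open, as far as these compounds go, is how the number moves when the remaining hydroxy group of compound 4 gives way to hydrogen or to an amine. Also open, from the compounds shown here alone, is whether any other pair on either core follows the same direction.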